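A few compounds are considered here, and "the series" means these few. Any claim that something is new, unique, unknown or untested is made for them only; others in the source may bear on it.

Compound 2 `O=C(COc1ccc(/C=C2\SC(=O)NC2=O)cc1)Nc1ccccn1` carries a pyridin-2-yl group on the amide nitrogen of the shared core. In a functional assay on KB cells (Homo sapiens) for cytotoxicity, read by sulforhodamine B assay, with a stated time of 48 h (a higher number here means a weaker inhibitor of growth, a lower number a stronger inhibitor of growth), compound 2 gives only a limit, < 100000 nM, and so no number for it is known. Its measured neighbour is compound 1 `Cc1cnc(NC(=O)COc2ccc(/C=C3\SC(=O)NC3=O)cc2)s1`, which bears a 5-methyl-1,3-thiazol-2-yl group at the same amide nitrogen. In this assay compound 1 also gives only a limit, < 100000 nM. For the measured compounds named here, the one measured step, a step that the two limits leave unreadable from compound 1 to compound 2, cannot be read in size or direction because the limit of < 100000 nM in this assay, at which 2 of the 2 values shown sit, applies to both of its ends. Compound 3 `Cc1cc(NC(=O)COc2ccc(/C=C3\SC(=O)NC3=O)cc2)no1` differs from compound 2 by 5-methyl-1,2-oxazol-3-yl in place of pyridin-2-yl on an amide-type nitrogen. Going by the values given here, the only step that bears on this exchange, an earlier swap of one heteroaryl group for another at the same amide nitrogen, left both compounds at the limit, so nothing in the numbers points to a change in this assay beyond the scatter. Compound 3 is therefore expected to sit near the limit as well, with an estimated step of a number no lower from compound 2 to compound 3 (the limit leaves the size open). The estimate for compound 3 in this assay is 100000 nM, within 30000 nM to 300000 nM.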

Compound 3, concentration for total growth inhibition: < 100000 nM
Compound 3 gave a limit, no number; the forecaster's own chance of this, stated with the estimate: 80%; the middle value sits exactly at the limit.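

No new step can be read among compound 1, compound 2 and compound 3 in this assay, because each of the three gives only a limit: the limit of < 100000 nM in this assay, at which 3 of the 3 values shown sit.

The compounds shown leave open whether pyridin-2-yl, 5-methyl-1,3-thiazol-2-yl and 5-methyl-1,2-oxazol-3-yl on the amide nitrogen differ at all in this assay.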